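Replacing a Methoxyphenyl Amide with a Small Heterocyclic Ring

A few compounds are considered here, and "the series" means these few. Any claim that something is new, unique, unknown or untested is made for them only; others in the source may bear on it.

Measured so far:
compound 1 `COc1ccc2nc(C)cc(OC(C)C(=O)Nc3cc(C)cc(C)c3)c2c1`: 39800 nM
compound 2 `COc1ccc2nc(C)cc(OCCNc3cc(C)cc(C)c3)c2c1`: 31600 nM
compound 3 `COc1cccc(NC(=O)COc2cc(C)nc3ccc(OC)cc23)c1`: > 100000 nM

In a toxicity assay on HepG2 cells (Homo sapiens) for inhibition, read by CellTiter-Glo, with a stated time of 48 h (a lower number here means a stronger inhibitor, a higher number a weaker inhibitor), compound 1 gives 39800 nM and compound 2 gives 31600 nM. The reading for compound 3 is a limit of the assay and not a number, > 100000 nM, because of the limit of > 100000 nM in this assay, at which 1 of the 3 values shown sits. So compound 3 stands at the weak end of what this assay can report.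

Compound 4 `COc1ccc2nc(C)cc(OCC(=O)NC3CONC3=O)c2c1` differs from compound 3 in one place: a group of 6 heavy atoms (3 carbon, 1 nitrogen, 2 oxygen; one five-membered non-aromatic ring with 2 hetero atoms) in place of a group of 8 heavy atoms (7 carbon, 1 oxygen; one six-membered aromatic ring of carbon only), on an amide-type nitrogen. Within the data shown here, no measured pair shows a change of this kind, and compound 3 already sits at the limit. In this assay the step is expected to be a number no higher from compound 3 to compound 4 (the limit leaves the size open), that is, nothing beyond the scatter. Compound 4 is therefore estimated at 100000 nM, with a range from 40000 nM to 300000 nM, most likely again reported only as a limit.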

Compound 4, half-maximal inhibitory concentration: > 100000 nM
Compound 4: only a limit was reported (the forecaster's own chance of this, stated with the estimate: 70%); the middle value sits exactly at the limit.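

Among these compounds, compound 3 and compound 4 are both reported only as limits in this assay, so no step between them can be read. The compounds shown leave open whether exchanging the 3-methoxyphenyl for the five-membered non-aromatic ring changes inhibition at all.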